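The source may hold more compounds than are shown below. What is called first, only, known or untested is meant among the compounds shown, and "the series" means these compounds.

For the measured compounds named here, compound 1 `COc1ccc2c(c1)OC(c1ccccc1)CC2n1cncn1` is the stronger of the two compounds measured so far: in an assay for binding affinity to Aromatase (Homo sapiens), using microsomes (a higher number here means a weaker inhibitor, a lower number a stronger inhibitor), compound 1 gives 1400 nM, while compound 2 `COc1ccc2c(c1)OC(c1ccccc1)CC2n1cnnc1` in this assay gives 31600 nM. Going by the values given here, the one step measured, a 23-fold higher number from compound 1 to compound 2 (1.35 log units; beyond the scatter), moves the point of attachment of the triazole on the saturated ring carbon and leaves the methoxy group untouched.

Compound 3 `Oc1ccc2c(c1)OC(c1ccccc1)CC2n1cncn1` differs from compound 1 by hydrogen in place of methyl on an oxygen on an aromatic ring. Among the compounds with values here, no measured step touches the methoxy group, so the triazole step gives no direct guide; it shows only that this core tolerates large swings in this assay. With the aryl ether changed and nothing else, a moderate shift in either direction is expected, and the step is estimated as a 1.4-fold higher number from compound 1 to compound 3 (0.15 log units; within the scatter). Compound 3 is therefore expected to give about 2000 nM in this assay, within the range 500 nM to 8000 nM.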

Compound 3, half-maximal inhibitory concentration: 430 nM
For compound 3 the middle estimate is 4.7-fold (0.67 log units) above the measured one, and the stated range ends above it.
By their numbers in this assay, from the lowest: compound 3; then compound 1; then compound 2.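

Methoxy to hydroxy gives a 3.3-fold lower number from compound 1 to compound 3 (0.51 log units; beyond the scatter) in this assay, the first reading at this oxygen on an aromatic ring. The position therefore responds to what sits on the oxygen, and with the 1H-1,2,4-triazol-1-yl group kept, the methyl can be lost without any loss of inhibition in this series. No measurement shown here bears on the reason for this shift.

The compounds shown carry only methyl or hydrogen on this oxygen, so it stays open whether the lower number depends on the free hydroxy or simply on the loss of the methyl, and a longer chain such as ethyl on the oxygen, or an amine in place of the hydroxy, would help to separate the two. Going by these compounds, whether the same step holds alongside the 4H-1,2,4-triazol-4-yl group of compound 2 also stays open.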